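Swapping a Thiophene for a Nitrophenyl Arm

The compounds below may be only part of what the source reports. "The series", "measured", "known", "first", "only" and "open" are said of these compounds alone.

Measured so far:
Compound 1, `O=C1C(O)=C(C(c2cccs2)c2c[nH]c3ccccc23)C(=O)c2ccccc21`: 31300 nM
Compound 2, `O=C1C(O)=C(C(c2ccc([N+](=O)[O-])cc2)c2c[nH]c3ccc(Br)cc23)C(=O)c2ccccc21`: 45200 nM

Both compounds were tested in a toxicity assay (Homo sapiens) for cytotoxicity, read by MTT assay, with a stated time of 48 h; on this read-out lower numbers stand for stronger inhibition and higher numbers for weaker inhibition. Compound 1 gives 31300 nM in this assay, and compound 2 gives 45200 nM. Of these two numbers compound 1 has the lower one, but the gap to compound 2 lies within the usual scatter of repeated measurements, so the two compounds cannot really be told apart on this read-out.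

Compound 3 `O=C1C(O)=C(C(c2cccc([N+](=O)[O-])c2)c2c[nH]c3ccccc23)C(=O)c2ccccc21` has not yet been measured. It differs from compound 1 in one place: 3-nitrophenyl in place of thiophen-2-yl on a saturated chain carbon bound to an aromatic carbon and a double-bonded ring carbon. For the measured compounds named here, no measured pair shows what this change does on its own. Going by the values given here, the only guide is that compound 2, which also carries a nitrophenyl group on the same saturated chain carbon, gives 45200 nM, a number not distinguishable from that of compound 1. On this basis the expected step is a 1.2-fold higher number from compound 1 to compound 3 (0.06 log units; within the scatter), with no clear direction beyond the scatter. Compound 3 is therefore estimated at 36000 nM in this assay, within a range from 15000 nM to 85000 nM.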

Compound 3, half-maximal inhibitory concentration: 91200 nM
Beside the measured number, compound 3's estimate is 2.5-fold (0.40 log units) below it; the whole stated range lies below it.
By their numbers in this assay, from the lowest: compounds 1, 2 and 3 (each within the scatter of the next, the first and the last beyond it).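

For the compounds shown here, this is the first single change at this position that can be read on its own: in this assay, putting 3-nitrophenyl in place of thiophen-2-yl on the saturated chain carbon gives a 2.9-fold higher number from compound 1 to compound 3 (0.46 log units; beyond the scatter). The group held on this carbon therefore does move the read-out, and in this one pair the larger arm, with 9 heavy atoms against 5, goes with weaker inhibition, although the step is only modest and a single pair sets no general rule. Nothing measured here explains why the number rises.

The change replaces the five-membered ring with a six-membered one and also brings in a nitro group, so this pair cannot show which of the two accounts for the step. A plain phenyl on the same carbon would separate the ring from the nitro group, and a phenyl ring carrying an amine or a carboxylic acid instead of the nitro group would show whether the step depends on the nitro group itself.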